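Sulfur side chain: from compound 2 to compound 3

The source may report more compounds than this note shows. Statements on the series, on what has been measured and on what is new or still open speak of the compounds shown alone.

In a functional assay on HT cells (Homo sapiens) for antiproliferative activity, read by fluorescence, with a stated time of 72 h (a lower number here means a stronger inhibitor of growth, a higher number a weaker inhibitor of growth), compound 1 `CC(C)c1n[nH]c2c(NCc3ccc(-c4ccccn4)cc3)nc(SCC(O)CO)nc12` gives 21 nM and compound 2 `CC(C)c1n[nH]c2c(NCc3ccc(-c4ccccn4)cc3)nc(SCC(C)(C)O)nc12` gives 507 nM, the higher of the two numbers. Compound 3 `CC(C)c1n[nH]c2c(NCc3ccc(-c4ccccn4)cc3)nc(SC(CO)C(C)C)nc12` carries 1-(hydroxymethyl)-2-methylpropyl in place of 2-hydroxy-2-methylpropyl on a sulfur. Among the measured compounds shown here, the only measured step on this chain is large and beyond the scatter: a 24-fold higher number from compound 1 to compound 2 (1.38 log units; beyond the scatter). Compound 3 has a hydroxymethyl, as the chain of compound 1 does, and compound 2 has none, so a partial return towards a lower number is expected. The expected change is a 4.6-fold lower number from compound 2 to compound 3 (0.66 log units; beyond the scatter). For compound 3 the estimated value is 110 nM, with an expected range of 30 nM to 400 nM.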

Compound 3, concentration for 50% growth inhibition: 980 nM
Compound 3: middle estimate off by 8.9-fold (0.95 log units), on the low side, outside the stated range (above it).
By their numbers in this assay, from the lowest: compound 1; then compounds 2 and 3 (each within the scatter of the next).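

In this assay, a hydroxymethyl on the sulfur chain does not by itself bring back the low number of compound 1: the data show a 1.9-fold higher number from compound 2 to compound 3 (0.29 log units; within the scatter) and a 47-fold higher number from compound 1 to compound 3 (1.67 log units; beyond the scatter). Thus 2,3-dihydroxypropyl stands apart from both 2-hydroxy-2-methylpropyl and 1-(hydroxymethyl)-2-methylpropyl, which this assay does not separate. Nothing available gives a reason for this gap.

As far as these compounds go, it remains open whether the lower number goes with the second hydroxyl of 2,3-dihydroxypropyl or with its unbranched chain. Also open, from the compounds shown here alone, is how an amine or a carboxylic acid on a longer chain on the sulfur would compare.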